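Shrinking an isopropyl to methyl on the pyrimidine-bound ring

A few compounds are considered here, and "the series" means these few. Any claim that something is new, unique, unknown or untested is made for them only; others in the source may bear on it.

Measured so far, in a functional assay on MGC-803 cells (Homo sapiens) for inhibition, read by MTT assay, with a stated time of 72 h; on this read-out lower numbers stand for stronger inhibition and higher numbers for weaker inhibition:
- compound 1 `Cc1ccc(Nc2nc(SCc3cn(CC(=O)NC(=O)Nc4ccccn4)nn3)nc(-c3ccc(C(C)C)cc3)c2C#N)cc1`: 3360 nM
- compound 2 `Cc1cccc(Nc2nc(SCc3cn(CC(=O)NC(=O)Nc4ccccn4)nn3)nc(-c3ccc(C(C)C)cc3)c2C#N)c1`: 25300 nM
- compound 3 `CC(C)c1ccc(Nc2nc(SCc3cn(CC(=O)NC(=O)Nc4ccccn4)nn3)nc(-c3ccc(C(C)C)cc3)c2C#N)cc1`: 15800 nM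

Compound 1 has the lowest number of the three, so it is the strongest inhibitor here. Moving the methyl on the nitrogen-bound ring, as in a 7.5-fold higher number from compound 1 to compound 2 (0.88 log units; beyond the scatter), weakened inhibition, and so did enlarging that methyl to isopropyl, as in a 4.7-fold higher number from compound 1 to compound 3 (0.67 log units; beyond the scatter). Compounds 2 and 3 sit within the scatter of each other, as a 1.6-fold lower number from compound 2 to compound 3 (0.20 log units; within the scatter) shows.

Compound 4 `Cc1ccc(Nc2nc(SCc3cn(CC(=O)NC(=O)Nc4ccccn4)nn3)nc(-c3ccc(C)cc3)c2C#N)cc1` is not yet measured. It differs from compound 1 as follows: methyl in place of isopropyl on an aromatic carbon. Among the compounds with values here, no measured step touches this ring; the only size change seen, from compound 1 to compound 3, sits on the other ring and went from methyl to isopropyl, costing a 4.7-fold higher number from compound 1 to compound 3 (0.67 log units; beyond the scatter). That gives only a loose hint that alkyl size matters somewhere on the molecule, in either direction. A step of modest size, within or just beyond the scatter, is therefore expected: a 1.3-fold higher number from compound 1 to compound 4 (0.13 log units; within the scatter). For compound 4 in this assay the estimate is 4500 nM, with a range from 1500 nM to 14000 nM.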

Compound 4, half-maximal inhibitory concentration: 9890 nM
Compound 4: the middle estimate sits 2.2-fold (0.34 log units) below what was measured; the range from low to high includes it.
By their numbers in this assay, from the lowest: compound 1; then compounds 4, 3 and 2 (each within the scatter of the next, the first and the last beyond it).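

Within the data shown here, this is the first measured change at this position, and in this assay replacing 4-isopropylphenyl with 4-methylphenyl weakens inhibition, giving a 2.9-fold higher number from compound 1 to compound 4 (0.47 log units; beyond the scatter) beyond the scatter. The alkyl group here therefore matters, and the preference runs opposite to that on the nitrogen-bound ring, where isopropyl rather than methyl gives the higher number, seen in a 4.7-fold higher number from compound 1 to compound 3 (0.67 log units; beyond the scatter) as a step of similar modest size. The data offer no measured explanation for the loss of inhibition at this position.

Going by these compounds, with only isopropyl and methyl compared here, it remains open whether a longer chain such as butyl, a tert-butyl group, or a methoxy group would do better or worse than isopropyl. On these data alone, it is also open whether isopropyl keeps its advantage when the nitrogen-bound ring carries something other than 4-methylphenyl.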